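Methyl to methoxy on the shared core, compound 3

The compounds below may be only part of what the source reports. "The series", "measured", "known", "first", "only" and "open" are said of these compounds alone.

Measured so far:
compound 1, `O=C(NO)c1ccc(CN2C(=O)/C(=C3\Nc4ccccc4\C3=N/O)c3cc(Cl)ccc32)cc1`, in an assay on isolated protein for inhibition of protein deacetylase HDAC6 (Homo sapiens) (a lower number here means a stronger inhibitor, a higher number a weaker inhibitor), compound 1 gives 16 nM.
compound 2, `Cc1ccc2c(c1)/C(=C1/Nc3ccccc3/C1=N\O)C(=O)N2Cc1ccc(C(=O)NO)cc1`, in this assay compound 2 gives 20 nM.

Compound 2 holds the higher of the two numbers in this assay, but the gap between the two is only a 1.3-fold higher number from compound 1 to compound 2 (0.10 log units; within the scatter), so the two stand together within the scatter.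

Compound 3, `COc1ccc2c(c1)/C(=C1/Nc3ccccc3/C1=N\O)C(=O)N2Cc1ccc(C(=O)NO)cc1`, is not yet measured. It differs from compound 2 by methoxy in place of methyl on an aromatic carbon.

For the measured compounds named here, only one measured step speaks to substitution at this carbon of the shared core: the move a 1.3-fold higher number from compound 1 to compound 2 (0.10 log units; within the scatter), which exchanged one small group for another at the same place and moved the number by less than the scatter. Going by the values given here, no step with a methoxy at this or any other position is available, so the bearing of this step on the new change is indirect. On that basis, compound 3 is expected to stay close to compound 2 in this assay, with a step of a 1.3-fold higher number from compound 2 to compound 3 (0.10 log units; within the scatter) that is not expected to exceed the scatter in either direction. The estimate for compound 3 is 25 nM, with a range from 10 nM to 60 nM.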

Compound 3, half-maximal inhibitory concentration: 30 nM
Compound 3: the middle estimate sits 1.2-fold (0.08 log units) below what was measured, within the range that was stated.
By their numbers in this assay, from the lowest: compounds 1, 2 and 3 (each within the scatter of the next).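

In this assay the exchange of methyl for methoxy, which brings an oxygen and a hydrogen-bond acceptor onto this aromatic carbon, stays within the scatter (a 1.5-fold higher number from compound 2 to compound 3 (0.18 log units; within the scatter)), so this position tolerates the change with no readable shift in the number. The exchange of chloro for methoxy at the same carbon also stays within the scatter (a 1.9-fold higher number from compound 1 to compound 3 (0.27 log units; within the scatter)), even though it is the largest gap among the three compounds, so chloro, methyl and methoxy cannot be placed in any order here and all three remain compatible with a number in the same narrow band. No measurement at hand bears on why these groups stand so close together.

The compounds shown leave open whether a group of a different kind at this carbon, such as an amine, a carboxylic acid or a longer alkoxy chain, would move the number beyond the scatter. Also open is whether the same tolerance holds for methoxy on other aromatic carbons of the shared core, and beyond this assay nothing is shown about these compounds.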